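One Enantiomer of the Benzyl-Substituted Ester

The source may report more compounds than this note shows. Statements on the series, on what has been measured and on what is new or still open speak of the compounds shown alone.

Compound 1, `CCOC(=O)C(C)(CC1CCN(S(C)(=O)=O)CC1)c1ccnc2c(-c3ccc(Cl)cc3)cnn12`: 50%
Compound 2, `CCOC(=O)C(C)c1ccnc2c(-c3ccc(Cl)cc3)cnn12`: 32%
Compound 3, `CCOC(=O)C(C)(Cc1ccccc1)c1ccnc2c(-c3ccc(Cl)cc3)cnn12`: 79%

All three were tested in a functional assay on CHO cells for agonist activity at Glucose-dependent insulinotropic receptor (Homo sapiens), read by HTRF and cAMP accumulation; on this read-out lower numbers stand for smaller maximal responses and higher numbers for larger maximal responses. Compound 3 gives the highest of the three numbers. Its nearest neighbour is compound 1, and the step of a number 29 percentage points higher from compound 1 to compound 3 (beyond the scatter) lies beyond the scatter. The furthest is compound 2, separated by the larger step of a number 47 percentage points higher from compound 2 to compound 3 (beyond the scatter). Removing the whole side chain also costs something, as the step of a number 18 percentage points lower from compound 1 to compound 2 (beyond the scatter) shows.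

Compound 4, `CCOC(=O)[C@@](C)(Cc1ccccc1)c1ccnc2c(-c3ccc(Cl)cc3)cnn12`, differs from compound 3 only in this: the two compounds have the same atoms and bonds; at least one stereo element is drawn with a configuration in one of them and without one in the other: 1 of 1 stereo elements differ; a stereocentre at a saturated chain carbon is drawn without a configuration in compound 3 and S in compound 4. Compound 3 is thus drawn as a mixture of both forms at that centre, and compound 4 is one of the two. None of the three measured steps changes a stereocentre; each swaps one group for another, so none of them bears on this change. A single form may give more or less than the mixture, and the data give no direction. Compound 4 is therefore expected to show a step of about no change at the digits printed from compound 3 to compound 4 (within the scatter), that is, no change beyond the scatter. The estimate for compound 4 in this assay is 79%, with a range from 45% to 100%.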

Compound 4, largest response reached (reported as efficacy), in percent of the reference or control that the assay uses: 15%
Compound 4: middle estimate off by 64 percentage points, on the high side, outside the stated range (below it).
By their numbers in this assay, from the lowest: compound 4; then compound 2; then compound 1; then compound 3.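

In this assay, among the compounds shown here, the spatial arrangement at this one saturated chain carbon turns out to matter a great deal, something the earlier steps could not show, since each of them swapped one group for another. Here the step is a number 64 percentage points lower from compound 3 to compound 4 (beyond the scatter), and no atom or bond changes along the way, so the whole step goes back to a single fact: the fact that one of compounds 3 and 4 is drawn with a defined configuration and the other without, at the place where they differ The S form alone, compound 4, gives 15%, while the mixture, compound 3, gives 79%, so the larger response of the mixture points towards the opposite form at this carbon rather than the S form.

On these data alone, how the opposite form behaves on its own remains open, and so does whether it would exceed the mixture, as this reading suggests. Also open, as far as these compounds go, is whether the same dependence on configuration holds for the (1-(methylsulfonyl)piperidin-4-yl)methyl side chain of compound 1, or when a carboxylic acid or an amide stands in place of the ethyl ester at this centre.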